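A few compounds are considered here, and "the series" means these few. Any claim that something is new, unique, unknown or untested is made for them only; others in the source may bear on it.

For the measured compounds named here, compound 1 `N#C/C(=C\C=C(/Cl)c1ccc(Br)cc1)C(=O)c1c[nH]c2ccccc12` carries a core that differs from the one shared by compound 2 `COc1ccc(/C(Cl)=C/C=C(\C#N)C(=O)c2c[nH]c3ccccc23)cc1OC` and compound 3 `COc1ccc(/C(Cl)=C/C=C(\C#N)C(=O)c2c(C)[nH]c3ccccc23)cc1OC`; the difference between the two cores is not broken down here. In a functional assay for inhibition, with a stated time of 5 min, tested at 1 mM (on this read-out higher numbers stand for more inhibition at the one concentration tested (going by the name of the read-out) and lower numbers for less inhibition), compound 1 gives 65.5%. In this assay compound 2 gives 63.6%, and compound 3 gives 66.4%. Going by the values given here, the single change from compound 2 to compound 3 is methyl in place of hydrogen on an aromatic carbon, and it made a step of a number 2.8 percentage points higher from compound 2 to compound 3 (within the scatter). The same change, at the same place, turns compound 1 into compound 4 `Cc1[nH]c2ccccc2c1C(=O)/C(C#N)=C/C=C(\Cl)c1ccc(Br)cc1`: methyl in place of hydrogen on an aromatic carbon. Because the step of a number 2.8 percentage points higher from compound 2 to compound 3 (within the scatter) stays within the scatter, compound 4 is expected to show a step of about a number 1.5 percentage points higher from compound 1 to compound 4 (within the scatter) beside the earlier one. Compound 4 is therefore estimated at 67%, between 57% and 77%.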

Compound 4, a percentage reported as inhibition, at one concentration (the size of the read-out at that concentration, not a potency): 69.1%
Compound 4: the middle estimate sits 2.1 percentage points below what was measured; measured number inside the range.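

On the core of compound 1, methyl in place of hydrogen on an aromatic carbon gave a step of a number 3.6 percentage points higher from compound 1 to compound 4 (within the scatter) in this assay. Set beside the earlier step, the change carried from one core to the other with no difference that can be told apart: the same change on two cores in this assay, a number 2.8 percentage points higher (within the scatter) from compound 2 to compound 3 and a number 3.6 percentage points higher (within the scatter) from compound 1 to compound 4, 0.8 percentage points apart, within the scatter of two such steps. This shows that on these two cores the step stays within the scatter at the one concentration tested; it does not show that methyl truly raises inhibition, nor does it set a rule for the wider series.

The compounds shown leave open whether ethyl, a longer chain or a carboxylic acid on that aromatic carbon would give a step beyond the scatter. From the compounds shown here alone, how the methyl change behaves on any further core also remains open.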